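A Side Chain Rearranged: Isopentyl to Neopentyl

This account rests on a few compounds, and the source may have more. Where it says the series, first, only, none or still open, it means among the compounds named here.

Of the compounds shown here, three built on a shared core have been measured in a physicochemical assay for lipophilicity; on this read-out lower numbers stand for lower lipophilicity and higher numbers for higher lipophilicity: compound 1 `Cc1ccc(NC(=O)C[C@H](CCC(=O)O)c2noc(-c3ncc(CC(C)C)s3)c2C2CC2)c(Cl)c1`, compound 2 `Cc1ccc(NC(=O)C[C@H](CCC(=O)O)c2noc(-c3noc(CC(C)C)n3)c2C2CC2)c(Cl)c1` and compound 3 `Cc1ccc(NC(=O)C[C@H](CCC(=O)O)c2noc(-c3cc(CCC(C)C)on3)c2C2CC2)c(Cl)c1`. Compound 1 gives 4, compound 2 gives 3.6 and compound 3 gives 4.3. Compound 3 thus stands level with compound 1 within the scatter, and both stand clear of compound 2.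

Compound 4 `Cc1ccc(NC(=O)C[C@H](CCC(=O)O)c2noc(-c3cc(CC(C)(C)C)on3)c2C2CC2)c(Cl)c1` keeps the atoms of compound 3 but joins them differently: tert-butyl in place of isobutyl on a saturated chain carbon bound to an aromatic carbon. In words, tert-butyl takes the place of isobutyl on a saturated chain carbon bound to an aromatic carbon, which turns isopentyl into neopentyl.

Going by the values given here, no measured step makes this change on its own. Each one replaces the whole group on an aromatic carbon. These steps are a number 0.40 log units lower from compound 1 to compound 2 (beyond the scatter), a number 0.70 log units higher from compound 2 to compound 3 (beyond the scatter) and a number 0.30 log units higher from compound 1 to compound 3 (within the scatter). Even the modest ones therefore involve a much larger structural change than the rearrangement in compound 4, so they offer only a loose upper guide to its size. The expected change is a number 0.10 log units lower from compound 3 to compound 4 (within the scatter), which would be no step beyond the scatter. For compound 4, the estimated value in this assay is 4.2, with an expected range from 3.8 to 4.6.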

Compound 4, distribution coefficient: 4.2
For compound 4 middle estimate and measured number coincide at the digits printed; low and high end bracket the measured number.
By their numbers in this assay, from the lowest: compound 2; then compounds 1, 4 and 3 (each within the scatter of the next).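

In this assay, the move from isopentyl to neopentyl, with tert-butyl in place of isobutyl on a saturated chain carbon bound to an aromatic carbon, gives a number 0.10 log units lower from compound 3 to compound 4 (within the scatter) and is the first step shown that changes only how the side chain is joined, so at this position the two arrangements of the same atoms cannot be told apart on this read-out. The wider picture stays as it was, with one step reading a number 0.60 log units higher from compound 2 to compound 4 (beyond the scatter) and the other reading a number 0.20 log units higher from compound 1 to compound 4 (within the scatter) even though each of these also swaps the whole group on the aromatic carbon. No measured evidence is at hand to explain this result.

Still open, on these data alone, is how this assay would respond to a side chain that is not purely carbon, such as one ending in an amine or a carboxylic acid, or to a longer chain or a cyclohexyl group at the same place. As far as these compounds go, the rearrangement has also been read on only one side chain and one ring, so whether the same swap would stay within the scatter on 5-isobutyl-1,3-thiazol-2-yl or 5-isobutyl-1,2,4-oxadiazol-3-yl remains unknown.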